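The source may hold more compounds than are shown below. What is called first, only, known or untested is meant among the compounds shown, and "the series" means these compounds.

Measured compounds:
compound 1 `CN1C(=O)C(c2ccccc2)N(C)c2nc(Nc3ccc(S(N)(=O)=O)cc3)ncc21` gives 383 nM in an assay on Sf9 cells for inhibition of serine/threonine-protein kinase 4 (Homo sapiens), read by luminescence and ADP-Glo, with a stated time of 1 h, in the presence of a further agent that is not named here; on this read-out higher numbers stand for weaker inhibition and lower numbers for stronger inhibition
compound 2 `CN1C(=O)C(c2ccccc2C(F)(F)F)N(C)c2nc(Nc3ccc(S(N)(=O)=O)cc3)ncc21` gives 56 nM
compound 3 `CN1C(=O)C(c2ccccc2Br)N(C)c2nc(Nc3ccc(S(N)(=O)=O)cc3)ncc21` gives 57 nM

Of the three numbers, compound 3 stands second highest. One of its steps lies within the scatter: a 1.0-fold higher number from compound 2 to compound 3 (0.01 log units; within the scatter). The other lies beyond it: a 6.7-fold lower number from compound 1 to compound 3 (0.83 log units; beyond the scatter).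

The next compound is compound 4 `Cc1c(F)cccc1C1C(=O)N(C)c2cnc(Nc3ccc(S(N)(=O)=O)cc3)nc2N1C`. The change from compound 3 is 3-fluoro-2-methylphenyl in place of 2-bromophenyl on a saturated ring carbon. For the measured compounds named here, two measured steps bear on substitution of that aromatic ring: a 6.8-fold lower number from compound 1 to compound 2 (0.84 log units; beyond the scatter) and a 6.7-fold lower number from compound 1 to compound 3 (0.83 log units; beyond the scatter), both modest and both toward lower numbers. The third step, a 1.0-fold higher number from compound 2 to compound 3 (0.01 log units; within the scatter), shows that exchanging one of these two substituents for the other leaves the number unchanged within the scatter. Going by the values given here, no measured compound carries a methyl or a fluorine on this ring, and none carries two substituents on it, so the effect of the new pattern is not covered by the data. The substituted ring is kept, which argues against a return toward compound 1; the expected outcome is therefore a number close to that of compound 3, within or only slightly beyond the scatter, with the direction uncertain. Compound 4 is expected at 85 nM, with a range from 30 nM to 250 nM. The expected step is a 1.5-fold higher number from compound 3 to compound 4 (0.17 log units; within the scatter).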

Compound 4, half-maximal inhibitory concentration: 419 nM
Estimate against measurement, compound 4: 4.9-fold (0.69 log units) below, and the stated range ends below it.
By their numbers in this assay, from the lowest: compounds 2 and 3 (each within the scatter of the next); then compounds 1 and 4 (each within the scatter of the next).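

In this assay, a substituent on the phenyl ring at this saturated ring carbon does not by itself bring the lower numbers: a 7.4-fold higher number from compound 3 to compound 4 (0.87 log units; beyond the scatter) and a 7.5-fold higher number from compound 2 to compound 4 (0.87 log units; beyond the scatter) are both beyond the scatter, so what holds for 2-bromophenyl and 2-(trifluoromethyl)phenyl does not carry over to 3-fluoro-2-methylphenyl. Against plain phenyl, the new ring shows no difference: a 1.1-fold higher number from compound 1 to compound 4 (0.04 log units; within the scatter) stays within the scatter, so the methyl and fluorine of compound 4 together give no measurable gain over the unsubstituted ring. This position therefore separates one substitution pattern from another, not merely substituted rings from the unsubstituted one, and nothing available here bears on the reason for the result.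

Open is which of the two substituents of compound 4 sets its number, since neither methyl nor fluorine stands alone on this ring in the compounds shown, and whether a chloro or a methoxy in place of the bromo would track compound 3 or compound 4. Also open, as far as these compounds go, is whether an amine or a carboxylic acid on this ring would be tolerated.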